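The compounds below may be only part of what the source reports. "The series", "measured", "known", "first", "only" and "open" are said of these compounds alone.

Measured compounds:
- compound 1, `NC(=O)N(O)CC1=Cc2cc(OCc3ccccc3)ccc2OC1`: 440 nM
- compound 2, `NC(=O)N(O)CC1=Cc2cc(OCC3CCCCC3)ccc2OC1`: 1360 nM
- compound 3, `NC(=O)N(O)CC1=Cc2cc(OCCCc3ccccc3)ccc2OC1`: 130 nM

All three were tested in an assay (Cavia porcellus) for inhibition of Polyunsaturated fatty acid 5-lipoxygenase (Homo sapiens); a lower number here means a stronger inhibitor, a higher number a weaker inhibitor. Compound 2 gives the highest number of the three; its two steps are a 3.1-fold higher number from compound 1 to compound 2 (0.49 log units; beyond the scatter), read in reverse, and a 10-fold lower number from compound 2 to compound 3 (1.02 log units; beyond the scatter). Among the aryl-bearing members, compound 3 is separated from compound 1 by a 3.4-fold lower number from compound 1 to compound 3 (0.53 log units; beyond the scatter).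

Compound 4, `NC(=O)N(O)CC1=Cc2cc(-c3ccccc3)ccc2OC1`, is the unmeasured member. Relative to compound 2 the change is phenyl in place of cyclohexylmethoxy on an aromatic carbon. Among the compounds with values here, no measured step makes the same change; the steps that bear on it are those in which a phenyl-containing group replaces the cyclohexyl-containing one, namely a 10-fold lower number from compound 2 to compound 3 (1.02 log units; beyond the scatter) and the reverse of a 3.1-fold higher number from compound 1 to compound 2 (0.49 log units; beyond the scatter), both running to lower numbers. Within the data shown here, since both point the same way, a lower number is expected for compound 4 in this assay, though the shorter link to the ring has no measured counterpart, so the size is uncertain. The expected step from compound 2 is a 3.0-fold lower number from compound 2 to compound 4 (0.48 log units; beyond the scatter). The estimate for compound 4 is 450 nM, with a range from 120 nM to 1800 nM.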

Compound 4, half-maximal inhibitory concentration: 240 nM
Estimate against measurement, compound 4: 1.9-fold (0.27 log units) above; measured number inside the range.
By their numbers in this assay, from the lowest: compounds 3, 4 and 1 (each within the scatter of the next, the first and the last beyond it); then compound 2.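

Directly on the aromatic carbon, phenyl stands in place of benzyloxy with no change beyond the scatter, a 1.8-fold lower number from compound 1 to compound 4 (0.26 log units; within the scatter), so among these compounds the oxygen-bearing link is not needed to hold a number in this range. Against the cyclohexylmethoxy compound, the phenyl group gives a 5.7-fold lower number from compound 2 to compound 4 (0.75 log units; beyond the scatter), which extends the earlier advantage of aromatic over cyclohexyl groups to a group with no chain at all. This step changes the ring type and removes the link at once, so its size cannot be assigned to either change, and no measurement on hand gives a reason for either step.

From the compounds shown here alone, a cyclohexyl group placed directly on the same aromatic carbon would separate those two changes, and how it compares remains open. Also open, going by these compounds, is how the directly attached phenyl responds to a substituent such as an amine or a carboxylic acid.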